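The compounds below may be only part of what the source reports. "The series", "measured", "known", "first", "only" and "open" are said of these compounds alone.

In a functional assay on HCT-116 cells (Homo sapiens) for cytotoxicity, read by MTT assay (a lower number here means a stronger inhibitor, a higher number a weaker inhibitor), compound 1 (`COc1ccc(/C=C/C(=O)c2c(O)cc(C)oc2=O)cc1`) gives > 100000 nM as a limit of the assay and not a number. Compound 2 (`CCOc1ccc(/C=C/C(=O)c2c(O)cc(C)oc2=O)cc1`) likewise gives > 100000 nM as a limit. Compound 3 (`Cc1cc(O)c(C(=O)/C=C/c2ccc(N(C)C)cc2)c(=O)o1`) gives > 100000 nM as a limit too, so it has no number of its own and stands level with the other two only as far as that limit shows.

The next analogue, compound 4 (`Cc1cc(O)c(C(=O)/C=C/c2ccc(C#N)cc2)c(=O)o1`), has cyano in place of dimethylamino on an aromatic carbon, para to a large group (cyano in place of dimethylamino on an aromatic carbon). The measured changes at that same place are (a step that the two limits leave unreadable from compound 1 to compound 3) and (a step that the two limits leave unreadable from compound 2 to compound 3), so neither gives a size to carry over. Within the data shown here, no measured compound carries cyano. Among the measured compounds shown here, the series so far offers one reading (the limit of > 100000 nM in this assay, at which 3 of the 3 values shown sit).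

In this assay no step beyond the scatter is expected, in either direction, and the estimated step is (a number no higher from compound 3 to compound 4 (the limit leaves the size open)). For compound 4 the estimate is 100000 nM with an expected range from 40000 nM to 250000 nM and a report as a limit is the likeliest outcome.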

Compound 4, half-maximal inhibitory concentration: 66000 nM
Compound 4: the middle estimate sits 1.5-fold (0.18 log units) above what was measured; the measured number falls inside the stated range.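

In this assay, the aromatic carbon para to a large group now carries a group with a number of its own, cyano in compound 4, while methoxy, ethoxy and dimethylamino stay at a limit of the assay: the limit of > 100000 nM in this assay, at which 3 of the 4 values shown sit.

The steps to cyano read an at least 1.5-fold lower number from compound 3 to compound 4 (0.18 log units; that floor lies within the scatter), an at least 1.5-fold lower number from compound 2 to compound 4 (0.18 log units; that floor lies within the scatter) and an at least 1.5-fold lower number from compound 1 to compound 4 (0.18 log units; that floor lies within the scatter). From the compounds shown here alone, each is a floor and not a size, so the change gives a reading no higher than those limits, and its true size stays open.

Going by these compounds, it remains open how a carboxylic acid or a chlorine on this same aromatic carbon would read in this assay, and whether any group here gives a step clearly beyond the scatter. Also open, on these data alone, is whether a change elsewhere on the shared core would bring a much lower number.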